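The source may report more compounds than this note shows. Statements on the series, on what has been measured and on what is new or still open speak of the compounds shown alone.

Compound 1 `Nc1sc2cnccc2c1C(=O)c1ccc(Cl)cc1` is the reference point of this small set. Among the compounds with values here, in an assay on CHO cells for displacement of a labelled ligand from adenosine receptor A1 (Homo sapiens), tested at 10 uM (on this read-out higher numbers stand for more inhibition at the one concentration tested (going by the name of the read-out) and lower numbers for less inhibition), compound 1 gives 50%, the highest of the two numbers so far. Within the data shown here, its one neighbour, compound 2 `Nc1sc2cnccc2c1C(=O)c1ccc(Cl)c(Cl)c1`, gives 0% in this assay, so the step is a number 50 percentage points lower from compound 1 to compound 2 (beyond the scatter), brought by chloro in place of hydrogen on an aromatic carbon.

The next compound, compound 3 `Cc1ccc(C(=O)c2c(N)sc3cnccc23)cc1`, differs from compound 1 by methyl in place of chloro on an aromatic carbon. Among the measured compounds shown here, no measured step exchanges chloro for methyl at this place; the one step available, from compound 1 to compound 2, adds a second chloro elsewhere on the same ring and is large, but it does not tell how the original chloro itself may be swapped. For the measured compounds named here, with no bearing step, no change beyond the scatter is assumed. Compound 3 is therefore expected near 45%, in a range from 15% to 75%. For compound 3 this corresponds to an expected step of a number 5 percentage points lower from compound 1 to compound 3 (within the scatter).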

Compound 3, a percentage reported as inhibition, at one concentration (the size of the read-out at that concentration, not a potency): 45%
The estimate for compound 3 equals the measured number at the digits printed; measured number inside the range.
By their numbers in this assay, from the lowest: compound 2; then compounds 3 and 1 (each within the scatter of the next).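

In this assay, methyl in place of chloro, para to a large group, gives a number 5 percentage points lower from compound 1 to compound 3 (within the scatter), so the two groups are not told apart at this place. The chloro of compound 1 is therefore not needed to hold the read-out at this level, since a single carbon in its place serves as well, whereas chloro in place of hydrogen at another aromatic carbon gave a number 50 percentage points lower from compound 1 to compound 2 (beyond the scatter). No supporting evidence bears on this result.

On these data alone, what an amine, a carboxylic acid or a longer chain would do at this place remains open, as does the read-out with hydrogen there. Also open, as far as these compounds go, is whether the large step seen with the second chloro would recur with methyl at the place studied here.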